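Working notes: anilino to anilinomethyl on the shared core

The source may report more compounds than this note shows. Statements on the series, on what has been measured and on what is new or still open speak of the compounds shown alone.

Measured so far in an assay on CHO cells for displacement of a labelled ligand from prostaglandin E2 receptor EP1 subtype (Homo sapiens); a higher number here means a weaker inhibitor, a lower number a stronger inhibitor:
compound 1, `Cc1ccc(S(=O)(=O)N(Cc2nnc(Cc3c(Cl)cccc3Cl)o2)c2cccc(Cl)c2C)cc1`: 63.1 nM
compound 2, `Cc1ccc(S(=O)(=O)N(Cc2nnc(Cc3ccc(Cl)cc3Cl)o2)c2cccc(Cl)c2C)cc1`: 63.1 nM
compound 3, `COc1ccc(Nc2nnc(CN(c3cccc(Cl)c3C)S(=O)(=O)c3ccc(C)cc3)o2)cc1`: 31.6 nM

Compound 3 gives the smallest of the three numbers as read, yet a 2.0-fold lower number from compound 1 to compound 3 (0.30 log units; within the scatter) and a 2.0-fold lower number from compound 2 to compound 3 (0.30 log units; within the scatter) both lie within the scatter, and no change at the digits printed from compound 1 to compound 2 (within the scatter) as well, so the three compounds are not separated in this assay.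

Compound 4 is `COc1ccc(NCc2nnc(CN(c3cccc(Cl)c3C)S(=O)(=O)c3ccc(C)cc3)o2)cc1`. It differs from compound 3 by ((4-methoxyphenyl)amino)methyl in place of (4-methoxyphenyl)amino on an aromatic carbon. Among the measured compounds shown here, the steps that bear on this position are those from the two benzyl compounds to the anilino compound: a 2.0-fold lower number from compound 1 to compound 3 (0.30 log units; within the scatter) and a 2.0-fold lower number from compound 2 to compound 3 (0.30 log units; within the scatter), each within the scatter. Compound 4 keeps the amine of compound 3 and regains a chain carbon at the ring, as in compound 1 and compound 2. Since neither variation moved the number beyond the scatter, no step beyond the scatter is expected for compound 4 in this assay, the expected step being a 1.6-fold higher number from compound 3 to compound 4 (0.20 log units; within the scatter). Compound 4 is therefore estimated at 50 nM, with a range from 15 nM to 200 nM.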

Compound 4, half-maximal inhibitory concentration: 20 nM
Compound 4: middle estimate off by 2.5-fold (0.40 log units), on the high side; the measured number falls inside the stated range.
By their numbers in this assay, from the lowest: compounds 4, 3, 1 and 2 (each within the scatter of the next, the first and the last beyond it).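

Extending (4-methoxyphenyl)amino to ((4-methoxyphenyl)amino)methyl on the shared core does not separate the two compounds in this assay (a 1.6-fold lower number from compound 3 to compound 4 (0.20 log units; within the scatter)), so this position accepts the added chain carbon. Unlike compound 3, compound 4 stands apart from both dichlorobenzyl compounds, with (4-methoxyphenyl)amino in place of the dichlorophenyl groups on the saturated chain carbon giving two modest steps beyond the scatter (a 3.2-fold lower number from compound 1 to compound 4 (0.50 log units; beyond the scatter); a 3.2-fold lower number from compound 2 to compound 4 (0.50 log units; beyond the scatter)). No supporting evidence bears on why this position responds in this way.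

The compounds shown do not tell whether the amine nitrogen or the methoxy group accounts for those two steps, and an ether oxygen in place of the amine would address that point. Going by these compounds, how a longer chain, or an amide carbonyl in the linking chain, would read in this assay also remains open.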